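A methyl group on the ring of compound 3

The source may report more compounds than this note shows. Statements on the series, on what has been measured and on what is new or still open speak of the compounds shown alone.

Going by the values given here, in a functional assay on the whole organism for antagonist activity, with Mus musculus as the target (a lower number here means that less compound is needed, a higher number that more compound is needed for the effect), compound 3 `CCOC(=O)N(C)C(C)C#CCn1ccnc1` gives 66 mg/kg as the higher of the two numbers so far, while compound 1 `COC(=O)N(C)C(C)C#CCn1cncc1C` gives 6.6 mg/kg with a gap beyond the scatter. Compound 2 `CCOC(=O)N(C)C(C)C#CCN1CCCC1` gives > 100 mg/kg as a limit of the assay and not a number. Among the compounds with values here, the only measured step of an at least 1.5-fold lower number from compound 2 to compound 3 (0.18 log units; that floor lies within the scatter) concerns another group and says nothing about a methyl. Compound 4 `CCOC(=O)N(C)C(C)C#CCn1cncc1C` differs by methyl in place of hydrogen on an aromatic carbon with methyl in place of hydrogen on an aromatic carbon, so that 1H-imidazol-1-yl becomes 5-methyl-1H-imidazol-1-yl. Compound 1 carries that group and gives 6.6 mg/kg in this assay so a lower number is expected. The expected change is a 4.4-fold lower number from compound 3 to compound 4 (0.64 log units; beyond the scatter) and probably lies beyond the scatter. For compound 4 the estimate is 15 mg/kg with an expected range of 5 mg/kg to 50 mg/kg in this assay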

Compound 4, dose for half-maximal effect: 17.3 mg/kg
Compound 4: the middle estimate sits 1.2-fold (0.06 log units) below what was measured, and the stated range covers the measured number.
By their numbers in this assay, from the lowest: compound 1; then compound 4; then compound 3. At a limit, above all of these: compound 2.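

In this assay, methyl in place of hydrogen on this aromatic carbon gives a 3.8-fold lower number from compound 3 to compound 4 (0.58 log units; beyond the scatter) and so shows directly that this single added carbon matters. Against the pyrrolidin-1-yl group the step is only a floor, an at least 5.7-fold lower number from compound 2 to compound 4 (0.76 log units; beyond the scatter) and no more, since compound 2 stands at a limit and not a number: the limit of > 100 mg/kg in this assay, at which 1 of the 4 values shown sits. At the other end of the molecule, methyl in place of hydrogen on a saturated chain carbon bound to an oxygen gives a 2.6-fold higher number from compound 1 to compound 4 (0.42 log units; beyond the scatter) and so moves the number the opposite way.

The compounds shown leave open whether an ethyl group or a chlorine atom on this aromatic carbon would serve as well as methyl.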